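The compounds below may be only part of what the source reports. "The series", "measured", "known", "first", "only" and "open" are said of these compounds alone.

In a functional assay for antagonist activity at sodium-dependent dopamine transporter (Mus musculus) (a lower number here means that less compound is needed, a higher number that more compound is needed for the effect), two compounds have been measured so far:

Compound 1 `Cc1c(Cl)cccc1N1CCN(CCCCOc2ccc3ccc(O)nc3c2)CC1` gives 2.8 umol/kg
Compound 2 `Cc1c(Br)cccc1N1CCN(CCCCOc2ccc3ccc(O)nc3c2)CC1` gives 2.1 umol/kg

Among the measured compounds shown here, compound 2 has the lower of these two numbers, and compound 1 is its only neighbour; the step of a 1.3-fold lower number from compound 1 to compound 2 (0.12 log units; within the scatter) lies within the scatter, so the two cannot be told apart on these data. Compound 3 `Cc1cccc(N2CCN(CCCCOc3ccc4ccc(O)nc4c3)CC2)c1C` has not yet been measured. It differs from compound 2 in one place: methyl in place of bromo on an aromatic carbon. For the measured compounds named here, the only measured step, the exchange of one halogen for another at this same position, bears on the new change only loosely: it was small, and a halogen-to-methyl exchange has no measured counterpart here. With nothing in the data pushing the number either way, the expected step of a 1.2-fold higher number from compound 2 to compound 3 (0.09 log units; within the scatter) is small and not beyond the scatter. Compound 3 is therefore estimated at 2.6 umol/kg, with a range from 1.2 umol/kg to 5.5 umol/kg.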

Compound 3, dose for half-maximal effect: 3.4 umol/kg
Compound 3: middle estimate off by 1.3-fold (0.12 log units), on the low side; the range from low to high includes it.
By their numbers in this assay, from the lowest: compounds 2, 1 and 3 (each within the scatter of the next).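

In this assay, among the compounds shown here, methyl is the first group at this position that is not a halogen, and exchanging bromo for it leaves compound 3 within the scatter of compound 2 (a 1.6-fold higher number from compound 2 to compound 3 (0.21 log units; within the scatter)), as does exchanging chloro for it (a 1.2-fold higher number from compound 1 to compound 3 (0.08 log units; within the scatter)). Across these three compounds, then, chloro, bromo and methyl on this aromatic carbon cannot be told apart, so a carbon group serves here as well as either halogen on these data. No measured evidence here accounts for this. Going by these compounds, what stays open is whether the number would hold with something other than these single-atom groups at this position, such as a methoxy group, an amine or a longer chain. Plain hydrogen in place of the group is equally open, so the data cannot yet say whether any group is needed here at all.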